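Swapping an aryl ether for a benzylamine on a diamine core

The source may hold more compounds than are shown below. What is called first, only, known or untested is meant among the compounds shown, and "the series" means these compounds.

For the measured compounds named here, compound 1, `Nc1cc(N)c2nc(-c3ccccc3)c(Oc3ccc(Cl)c(Cl)c3)nc2c1`, is the only member of this small set with a numerical result: in a functional assay on MCF7 cells (Homo sapiens) for inhibition, read by sulforhodamine B assay, with a stated time of 48 h (a higher number here means a weaker inhibitor of growth, a lower number a stronger inhibitor of growth), compound 1 gives 70800 nM. The two other results are limits of the assay rather than numbers. Compound 2, `COc1cc(CNc2nc3cc(N)cc(N)c3nc2-c2ccccc2)cc(OC)c1OC`, gives in this assay only a limit of < 50200 nM. Compound 3, `CCOC(=O)[C@H](CCC(=O)O)NC(=O)c1ccc(Oc2nc3cc(N)cc(N)c3nc2-c2ccccc2)cc1`, likewise reaches in this assay only a limit of < 100000 nM. Compound 4, `Nc1cc(N)c2nc(-c3ccccc3)c(NCc3ccc(F)cc3)nc2c1`, has not yet been tested. It differs from compound 1 in a single place: (4-fluorobenzyl)amino in place of 3,4-dichlorophenoxy on an aromatic carbon. Going by the values given here, compound 2 also attaches its side group to the shared core through a nitrogen rather than an oxygen, so the change toward compound 4 is not wholly new ground, but no pair of measured compounds differing in one place exists to gauge its size. The step from compound 1 is expected to be modest and toward stronger growth inhibition, a 2.4-fold lower number from compound 1 to compound 4 (0.37 log units; beyond the scatter). Compound 4 is therefore estimated to give 30000 nM in this assay, within 8000 nM to 90000 nM.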

Compound 4, concentration for total growth inhibition: < 100000 nM
Compound 4: a limit, no number (the forecaster's own chance of this, stated with the estimate: 30%); the middle value does not contradict the limit.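

In this assay compound 4 gives only a limit, < 100000 nM. The step between compound 1 and compound 4 therefore cannot be read. The compounds shown leave open whether (4-fluorobenzyl)amino in place of 3,4-dichlorophenoxy changes growth inhibition at all, and if so, in which direction and by how much.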